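Aryl variation on the amide-bearing ring nitrogen

The source may report more compounds than this note shows. Statements on the series, on what has been measured and on what is new or still open speak of the compounds shown alone.

Measured so far in a functional assay (brain) for inhibition, with Rattus norvegicus as the target; a higher number here means a weaker inhibitor, a lower number a stronger inhibitor:
- compound 1 `Cc1c(C)c2c(c(C)c1O)CCC(C)(C(=O)N1CCN(c3cc(N4CCCC4)nc(N4CCCC4)n3)CC1)O2`: 500 nM
- compound 2 `CCNc1cccnc1N1CCN(C(=O)C2(C)CCc3c(C)c(O)c(C)c(C)c3O2)CC1`: 12000 nM
- compound 3 `COc1ccccc1N1CCN(C(=O)C2(C)CCc3c(C)c(O)c(C)c(C)c3O2)CC1`: 15000 nM

Compound 3 gives the highest of the three numbers in this assay; its nearest neighbour is compound 2, the two lying within the scatter of each other, while compound 1 sits far lower. The next compound is compound 4 `Cc1c(C)c2c(c(C)c1O)CCC(C)(C(=O)N1CCN(c3ccccn3)CC1)O2`, which differs from compound 3 by pyridin-2-yl in place of 2-methoxyphenyl on an amine nitrogen in a ring. Among the compounds with values here, the only measured step that bears on this change is the exchange of one aryl group for another on the same ring nitrogen, a 1.3-fold higher number from compound 2 to compound 3 (0.10 log units; within the scatter), which stayed within the scatter. Within the data shown here, compound 1 shows that a different group at this nitrogen can carry a much lower number, but no single-point step to compound 1 is measured, and its value alone cannot be read as a trend. Two different aryl groups at this nitrogen have so far given near-identical numbers. The expected step is therefore a 1.2-fold lower number from compound 3 to compound 4 (0.06 log units; within the scatter), nothing beyond the scatter. Compound 4 is estimated at 13000 nM in this assay, with a range from 5000 nM to 35000 nM.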

Compound 4, half-maximal inhibitory concentration: 1000 nM
For compound 4 the middle estimate is 13-fold (1.11 log units) above the measured one, outside the stated range (below it).
By their numbers in this assay, from the lowest: compounds 1 and 4 (each within the scatter of the next); then compounds 2 and 3 (each within the scatter of the next).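

In this assay, the group on this amine nitrogen in a ring is not interchangeable after all: there is a 15-fold lower number from compound 3 to compound 4 (1.18 log units; beyond the scatter), and a 12-fold lower number from compound 2 to compound 4 (1.08 log units; beyond the scatter), a change of only hydrogen in place of ethylamino on an aromatic carbon. The near-identical numbers of compound 2 and compound 3, a 1.3-fold higher number from compound 2 to compound 3 (0.10 log units; within the scatter), therefore do not describe the position as a whole, and the ethylamino group alone separates compound 2 from compound 4 by a large step. Nothing measured here accounts for the size of these steps.

On these data alone, it remains open whether the lower number of compound 4 goes with the ring nitrogen of pyridin-2-yl or with the lack of a further group on the aromatic ring, a question that a plain phenyl on the same nitrogen would address. As far as these compounds go, how methoxy or amino on pyridin-2-yl would read in this assay also remains open.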